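The compounds below may be only part of what the source reports. "The series", "measured", "known", "first", "only" and "open" are said of these compounds alone.

Compound 1 (`Cc1ccc(S(=O)(=O)N/N=C2\C(=O)Nc3ccc(S(=O)(=O)N4CCOCC4)cc32)cc1`) gives 261000 nM 
Compound 2 (`O=C1Nc2ccc(S(=O)(=O)N3CCOCC3)cc2/C1=N/NC(=O)c1ccccc1`) gives 295000 nM 

Going by the values given here, in an ADME assay on WI-38 cells (Homo sapiens) for cytotoxicity, read by sulforhodamine B assay, with a stated time of 24 h (on this read-out lower numbers stand for stronger inhibition and higher numbers for weaker inhibition), compound 2 stands level with compound 1, the only other measured compound, and the two values lie within the scatter of each other. Compound 3 (`O=C1Nc2ccc(S(=O)(=O)N3CCOCC3)cc2/C1=N/Nc1ccccc1`) departs from compound 2 by phenyl in place of benzoyl on an amine nitrogen in short: phenyl in place of benzoyl on an amine nitrogen. Among the compounds with values here, only one measured step bears on this, a change on that same amine nitrogen: a 1.1-fold higher number from compound 1 to compound 2 (0.05 log units; within the scatter) stays within the scatter. Within the data shown here, no measured compound carries phenyl there, so this evidence is indirect. No shift beyond the scatter is therefore expected, and the estimated step is a 1.3-fold lower number from compound 2 to compound 3 (0.13 log units; within the scatter) at most a small one. For compound 3 the expected value is 220000 nM within an estimated range from 90000 nM to 400000 nM as a working guess.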

Compound 3, half-maximal inhibitory concentration: 262000 nM
Estimate against measurement, compound 3: 1.2-fold (0.08 log units) below; the range from low to high includes it.
By their numbers in this assay, from the lowest: compounds 1, 3 and 2 (each within the scatter of the next).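

On the amine nitrogen of the shared core, this assay now gives a reading for phenyl, a group without the carbonyl of benzoyl or the sulfonyl of (4-methylphenyl)sulfonyl: a 1.1-fold lower number from compound 2 to compound 3 (0.05 log units; within the scatter) and a 1.0-fold higher number from compound 1 to compound 3 (0.00 log units; within the scatter). The earlier step had compared only the sulfonyl-linked and carbonyl-linked groups, whereas all three groups now read level, so this read-out separates none of those shown at this position. Nothing available accounts for this level reading.

Going by these compounds, it remains open whether a group of another kind on this nitrogen, such as a longer alkyl chain, an amine or a carboxylic acid, would move the number beyond the scatter. On these data alone, all three compounds also share the rest of the core, so the effect of any change elsewhere is unknown.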